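Tail changes on the aryloxy chain of the isoflavone-type core

The compounds below may be only part of what the source reports. "The series", "measured", "known", "first", "only" and "open" are said of these compounds alone.

Measured so far in a functional assay on mitochondria (Cricetulus griseus) for inhibition of Monoamine oxidase (Homo sapiens), tested at 0.9 uM; a higher number here means a stronger effect of the compound at the concentration tested, a lower number a weaker effect:
- compound 1, `O=c1c(-c2ccc(O)cc2)coc2cc(OCCCBr)ccc12`: 67.7%
- compound 2, `O=c1c(-c2ccc(O)cc2)coc2cc(OCC(O)CO)ccc12`: 63.8%

Among the measured compounds shown here, compound 2 and compound 1 cannot be told apart on these two numbers: the only step between them, a number 3.9 percentage points lower from compound 1 to compound 2 (within the scatter), falls inside the usual scatter of this read-out, so compound 2 is neither separated from nor ranked against compound 1 on what has been measured.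

Compound 3, `O=C(O)CCCCCCOc1ccc2c(=O)c(-c3ccc(O)cc3)coc2c1`, is not yet measured. It differs from compound 2 in one place: 5-carboxypentyl in place of 1,2-dihydroxyethyl on a saturated chain carbon bound to an oxygen on an aromatic ring.

For the measured compounds named here, the one measured step that bears on this change is the one at the same place, from compound 1 to compound 2, where the 2-bromoethyl tail gave way to the 1,2-dihydroxyethyl tail and the number moved only within the scatter. The change into compound 3 is larger in what it counts, yet it again touches only the tail on the saturated chain carbon bound to an oxygen on the aromatic ring, with the shared core untouched. Because a number 3.9 percentage points lower from compound 1 to compound 2 (within the scatter) stayed within the scatter, no step beyond the scatter is expected here either; the expected step is a number 0.8 percentage points lower from compound 2 to compound 3 (within the scatter).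

The estimate for compound 3 in this assay is 63%, expected within 46% to 78%.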

Compound 3, a percentage reported as inhibition, at one concentration (the size of the read-out at that concentration, not a potency): 71.2%
Estimate against measurement, compound 3: 8.2 percentage points below; measured number inside the range.
By their numbers in this assay, from the lowest: compounds 2, 1 and 3 (each within the scatter of the next).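

Working notes on the tail: the end group now covers bromo, a diol and a carboxylic acid, and this assay separates none of them. 5-carboxypentyl in place of 1,2-dihydroxyethyl gives a number 7.4 percentage points higher from compound 2 to compound 3 (within the scatter) and, cut further along the chain, 3-carboxypropyl in place of bromo gives a number 3.5 percentage points higher from compound 1 to compound 3 (within the scatter) on the same shared core. What compound 3 adds is tolerance of a much larger change at this place, 8 heavy atoms entering where 4 leave and a carboxylic acid at the chain end, with the read-out still inside the scatter of both compound 1 and compound 2. No measurement is available that would account for this flat picture.

Open, on these data alone, is whether any tail at this place separates from these three, for example an amine at the chain end, an ester or amide of the carboxylic acid, or a ring-bearing tail. Also open, as far as these compounds go, is how far chain length alone matters, since a shorter or longer chain with the same acid end would be needed to read it apart from the end group.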